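A few compounds are considered here, and "the series" means these few. Any claim that something is new, unique, unknown or untested is made for them only; others in the source may bear on it.

- Compound 1 `O=C1C(Nc2ccccc2F)=CC(=O)c2c1nc1n2[C@H]2OC[C@@H](O)[C@H]2OC1` gives > 4000 nM (a limit)
- Compound 2 `O=C1C(NC2CCCC2)=CC(=O)c2c1nc1n2[C@H]2OC[C@@H](O)[C@H]2OC1` gives > 16000 nM (a limit)

In a functional assay on MCF7 cells (Homo sapiens) for inhibition, read by sulforhodamine B assay (a higher number here means a weaker inhibitor, a lower number a stronger inhibitor), compound 2 gives > 16000 nM as a limit and not a number. Compound 3 `CCc1ccc(NC2=CC(=O)c3c(nc4n3[C@H]3OC[C@@H](O)[C@H]3OC4)C2=O)cc1` differs from compound 2 by 4-ethylphenyl in place of cyclopentyl on an amine nitrogen in one place: 4-ethylphenyl in place of cyclopentyl on an amine nitrogen. Within the data shown here, the one measured step bearing on this is a step that the two limits leave unreadable from compound 1 to compound 2 and it has no readable size. Compound 1 also has a phenyl group on that nitrogen and its > 4000 nM is a limit too. In this assay the expected change is an at least 2.0-fold lower number from compound 2 to compound 3 (0.30 log units; that floor lies within the scatter) as a rough estimate, a modest move toward stronger inhibition or none that can be read. Compound 3 is estimated at 8000 nM with a range from 2000 nM to 30000 nM and may again give only a limit.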

Compound 3, half-maximal inhibitory concentration: 8990 nM
Estimate against measurement, compound 3: 1.1-fold (0.05 log units) below, and the stated range covers the measured number.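

In this assay, among these compounds, compound 3 is the first compound here to give a number and not a limit, so 4-ethylphenyl on this amine nitrogen brings a readable value. Putting it in place of cyclopentyl gives an at least 1.7-fold lower number from compound 2 to compound 3 (0.25 log units; that floor lies within the scatter), and the true size of the step may be larger. That size stays a floor because compound 2 has only a limit: the limit of > 16000 nM in this assay, at which 1 of the 3 values shown sits.

From the compounds shown here alone, the step between compound 1 and compound 3 cannot be read, so how the two phenyl groups compare stays open. Also open, going by these compounds, is how a longer chain in place of ethyl, or an amine on the phenyl ring, would read.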